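The compounds below may be only part of what the source reports. "The series", "measured", "known", "first", "only" and "open" are said of these compounds alone.

In a functional assay on cells (Homo sapiens) for antiproliferative activity, read by MTT assay, with a stated time of 48 h (on this read-out higher numbers stand for weaker inhibition and lower numbers for stronger inhibition), compound 1 `CN(C)CCCn1c(N)c(-c2nc3ccccc3o2)c2nc(C#N)c(C#N)nc21` gives 5640 nM. Compound 2 `CCN(CC)CCn1c(N)c(-c2nc3ccccc3n2C)c2nc(C#N)c(C#N)nc21` is reported as > 50000 nM, which is a limit of the assay and not a number. Going by the values given here, its exact position is therefore unknown, and no measured step connects it with compound 1.

Compound 3 `CN(C)CCCn1c(N)c(-c2nc3ccccc3n2C)c2nc(C#N)c(C#N)nc21` differs from compound 2 in one place: (dimethylamino)methyl in place of diethylamino on a saturated chain carbon, two bonds along the chain from an aromatic nitrogen. Here (dimethylamino)methyl stands in place of diethylamino on a saturated chain carbon, two bonds along the chain from an aromatic nitrogen. Cut one bond further out, 2-(diethylamino)ethyl gives way to 3-(dimethylamino)propyl.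

Compound 1 carries the same 3-(dimethylamino)propyl chain and reaches 5640 nM, although it also differs from compound 3 elsewhere. That value is the only support for expecting a moderate shift toward stronger inhibition in this assay. The expected change is an at least 2.7-fold lower number from compound 2 to compound 3 (0.44 log units; beyond the scatter), an estimate that remains loose. For compound 3, the estimated value is 18000 nM, with an expected range from 5000 nM to 50000 nM.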

Compound 3, half-maximal inhibitory concentration: 3670 nM
For compound 3 the middle estimate is 4.9-fold (0.69 log units) above the measured one; measured number below the stated range.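

In this assay, this change on the saturated chain carbon, two bonds along the chain from an aromatic nitrogen, proves far from neutral, with an at least 13-fold lower number from compound 2 to compound 3 (1.13 log units; beyond the scatter) as the step that takes the series from a limit to a measured number. With the 3-(dimethylamino)propyl chain in place, the aromatic group matters little: 1-methyl-1H-benzimidazol-2-yl for 1,3-benzoxazol-2-yl gives a 1.5-fold lower number from compound 1 to compound 3 (0.19 log units; within the scatter) and so cannot be told apart from no change, which points to the chain rather than the aromatic group as the place where the two ends of this small set part. On these data alone, the true size of the chain step stays unknown because compound 2 stands at a limit of the assay, which is not a number: the limit of > 50000 nM in this assay, at which 1 of the 3 values shown sits.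

The compounds shown do not separate the two things that change together in this step, the alkyl groups on the amine and the length of the chain. A 2-(dimethylamino)ethyl chain or a 3-(diethylamino)propyl chain would tell these apart, and a ring amine such as morpholine at the chain end remains an open question.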